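Swapping Butyl for tert-Butyl on an Amide-Type Nitrogen

A few compounds are considered here, and "the series" means these few. Any claim that something is new, unique, unknown or untested is made for them only; others in the source may bear on it.

In a functional assay on L1210 cells (Mus musculus) for inhibition, read by MTT assay (on this read-out higher numbers stand for weaker inhibition and lower numbers for stronger inhibition), compound 3 (`CCCCNC(=O)N1CC1C#N`) gives 12000 nM and lies within the usual scatter of the other two measured compounds. Compound 1 (`CCOC(=O)CNC(=O)N1CC1C#N`) gives 13000 nM in this comparison and compound 2 (`N#CC1CN1C(=O)Nc1ccc(Cl)c(Cl)c1`) gives 7200 nM here. Compound 4 (`CC(C)(C)NC(=O)N1CC1C#N`) is built from compound 3 with tert-butyl in place of butyl on an amide-type nitrogen. For the measured compounds named here, no pair of measured compounds differs in just one place, so no direct precedent exists for this swap. Going by the values given here, the only guide is indirect: compound 3 at 12000 nM stays within the scatter of compound 1 and of compound 2, although all three carry different groups on that nitrogen. Three compounds are a thin basis, but they suggest no large shift in this assay for a rearranged butyl group. The expected step (a 1.1-fold higher number from compound 3 to compound 4 (0.03 log units; within the scatter)) is therefore none beyond the scatter. Compound 4 is estimated at 13000 nM (expected range 6000 nM to 28000 nM).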

Compound 4, half-maximal inhibitory concentration: 457000 nM
Compound 4: the middle estimate sits 35-fold (1.55 log units) below what was measured; the whole stated range lies below it.
By their numbers in this assay, from the lowest: compounds 2, 3 and 1 (each within the scatter of the next); then compound 4.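

In this assay the way the chain is joined on this amide-type nitrogen matters a great deal, with a 38-fold higher number from compound 3 to compound 4 (1.58 log units; beyond the scatter) even though the two compounds hold the same atoms. Compounds 1, 2 and 3 could not show this, since none of them differ in just one place and their values all lie within the scatter of one another. Nothing measured here explains why tert-butyl behaves so differently from butyl.

The compounds shown leave open whether this large step belongs to tert-butyl alone or also appears with other branched chains, such as isopropyl or sec-butyl. They also leave open whether a shorter chain such as ethyl, a longer one such as hexyl, or a ring such as cyclohexyl would stay close to compound 3 or move towards compound 4.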